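The source may hold more compounds than are shown below. What is called first, only, known or untested is meant among the compounds shown, and "the series" means these compounds.

Measured compounds:
Compound 1 `Cc1ccc2nc(Nn3c(-c4ccc([N+](=O)[O-])cc4)nnc3-c3cccnc3)sc2c1`: 64.4 ug/mL in an ADME assay on MT4 cells (Homo sapiens) for cytotoxicity, read by MTT assay, with a stated time of 5 days; a lower number here means that less compound is tolerated, a higher number that more compound is tolerated
Compound 2 `Clc1ccc(-c2nnc(-c3cccnc3)n2Nc2nc3ccc(Br)cc3s2)cc1`: 29.6 ug/mL in this assay

Of the two numbers in this assay, compound 2 has the lower one. Its nearest neighbour is compound 1, which tolerates more compound, and the gap between the two is beyond the usual scatter of repeated measurements.

Compound 3 `Cc1ccc2nc(Nn3c(-c4ccc(Cl)cc4)nnc3-c3cccnc3)sc2c1` has not yet been measured in this assay. It differs from compound 2 in one place: methyl in place of bromo on an aromatic carbon. Within the data shown here, no pair of measured compounds differing in just this one place is available, so the size of the step cannot be read from a direct comparison. What the measured numbers do show is that compound 1, which also carries a methyl, is the one that is tolerated at the higher level. On that basis the step from compound 2 to compound 3 is expected to be upward but small, and the expected step of a 1.5-fold higher number from compound 2 to compound 3 (0.18 log units; within the scatter) is not expected to exceed the usual scatter. Compound 3 is therefore estimated to give about 45 ug/mL, with a range from 22 ug/mL to 90 ug/mL.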

Compound 3, half-maximal cytotoxic concentration: 75.5 ug/mL
Compound 3: the middle estimate sits 1.7-fold (0.22 log units) below what was measured; low and high end bracket the measured number.
By their numbers in this assay, from the lowest: compound 2; then compounds 1 and 3 (each within the scatter of the next).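

In this assay, methyl in place of bromo on this aromatic carbon gives a 2.6-fold higher number from compound 2 to compound 3 (0.41 log units; beyond the scatter). This is the only direct reading of the change among these compounds. The two compounds differ in this one place alone, and the step shows that the choice between these two groups on the fused ring system matters in this read-out. The second comparison keeps the methyl in place and puts chloro in place of nitro on an aromatic carbon, giving a 1.2-fold higher number from compound 1 to compound 3 (0.07 log units; within the scatter); that step stays within the scatter, so this pair shows no separation between compound 1 and compound 3.

From the compounds shown here alone, with a single pair behind the methyl-for-bromo step, it remains open whether the same step would appear in a compound carrying nitro rather than chloro. Also open, going by these compounds, is how fluoro, methoxy or an amine on this same aromatic carbon would stand against methyl and bromo. Nothing measured here offers an explanation for the step between bromo and methyl.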